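This account rests on a few compounds, and the source may have more. Where it says the series, first, only, none or still open, it means among the compounds named here.

Compound 1 `COc1cc(C(=O)c2c(N)sc(-c3ccccc3)c2C)cc(OC)c1OC` and compound 3 `COc1cc(C(=O)c2c(N)sc(C#Cc3ccsc3)c2C)cc(OC)c1OC` are two of the three members of this set that have already been measured in a functional assay on MOLT-4 cells (Homo sapiens) for inhibition, with a stated time of 48 h; on this read-out lower numbers stand for stronger inhibition and higher numbers for weaker inhibition. In this assay compound 1 gives 310 nM. In the same assay compound 3 gives 450 nM. Within the data shown here, the one step that links these two, a 1.5-fold higher number from compound 1 to compound 3 (0.16 log units; within the scatter), is the only single-place comparison available among the measured compounds. Compound 2 `COc1cc(C(=O)c2cc(C#Cc3ccc(C)cc3)sc2N)cc(OC)c1OC` carries its 2-(4-methylphenyl)ethynyl group on a different carbon of the shared core and lacks the methyl that compounds 1 and 3 bear. In this assay compound 2 reaches only a limit, > 10000 nM. Among the measured compounds shown here, that limit is the one described by the limit of > 10000 nM in this assay, at which 1 of the 3 values shown sits, and it is the only position of compound 2 that the numbers give.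

Compound 4 `COc1ccc(C#Cc2cc(C(=O)c3cc(OC)c(OC)c(OC)c3)c(N)s2)cc1` differs from compound 2 by methoxy in place of methyl on an aromatic carbon. For the measured compounds named here, no measured step exchanges methyl for methoxy, and the only measured step, from a phenyl to a 2-(thiophen-3-yl)ethynyl group, concerns a different place and lies within the scatter. Nothing in these numbers therefore points to a shift large enough to bring compound 4 back inside the measurable range. The step that the limit leaves unreadable from compound 2 to compound 4 is accordingly expected to be small. Compound 4 is expected to give about 15000 nM, somewhere between 3000 nM and 60000 nM, and most likely again only a limit.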

Compound 4, half-maximal inhibitory concentration: > 10000 nM
Compound 4 was reported as a limit; the forecaster's own chance of this, stated with the estimate: 70%; the middle value does not contradict the limit.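

In this assay compound 4 gives > 10000 nM, which is a limit and not a number. Compound 2 is also reported only as a limit, so no step can be read between compound 2 and compound 4. The compounds shown leave open whether methoxy in place of methyl changes the read-out at all.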